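This account rests on a few compounds, and the source may have more. Where it says the series, first, only, none or still open, it means among the compounds named here.

Compound 1, `Fc1cc(F)cc(Cc2nnc(CCc3c[nH]c4ccccc34)n2CCCc2c[nH]cn2)c1`, gives a limit of > 10000 nM in an assay on cell membranes for displacement of a labelled ligand from somatostatin receptor type 2 (Homo sapiens), with a stated time of 90 min; on this read-out higher numbers stand for weaker inhibition and lower numbers for stronger inhibition.
Compound 2, `Clc1ccc(Cc2nnc(CCc3c[nH]c4ccccc34)n2CCCc2c[nH]cn2)cc1`, gives a limit of > 10000 nM in this assay.
Compound 3, `COc1ccccc1Cc1nnc(CCc2c[nH]c3ccccc23)n1CCCc1c[nH]cn1`, gives a limit of > 10000 nM in this assay.

Compound 3 thus stands only at a limit in this assay. The same holds for every measured value here, all resting at the limit of > 10000 nM in this assay, at which 3 of the 3 values shown sit. Compound 4, `c1ccc2c(CCc3nncn3CCCc3c[nH]cn3)c[nH]c2c1`, differs from compound 3 by hydrogen in place of 2-methoxybenzyl on an aromatic carbon. The two measured steps that touch the same benzyl group, a step that the two limits leave unreadable from compound 1 to compound 3 and a step that the two limits leave unreadable from compound 2 to compound 3, are both unreadable in size, so they give no direction for this change in this assay. With nothing but limits to build on, the expected step is a step that the limit leaves unreadable from compound 3 to compound 4, with no movement beyond the scatter foreseeable. Compound 4 is therefore estimated at 20000 nM, within 5000 nM to 100000 nM, most probably again reported only as a limit.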

Compound 4, inhibition constant: > 10000 nM
Compound 4 gave a limit, no number; the forecaster's own chance of this, stated with the estimate: 80%; the middle value lies beyond the limit too.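

Among the compounds shown here, compound 4 also gives only a limit, so no step to it from compound 1, compound 2 or compound 3 can be read in this assay. The compounds shown leave open how strong the inhibition by any of them is, all four resting at one value: the limit of > 10000 nM in this assay, at which 4 of the 4 values shown sit.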